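The compounds below may be only part of what the source reports. "The series", "measured", "known", "first", "only" and "open" are said of these compounds alone.

Compound 1 `Cc1cc(OC[C@@H]2CN(C)c3ccccc3O2)cc(C)c1C(=O)Nc1cccc(CC(=O)O)c1` gives > 10000 nM in an assay on CHO cells for displacement of a labelled ligand from prostacyclin receptor (Homo sapiens), read by scintillation counting, with a stated time of 30 min (on this read-out lower numbers stand for stronger inhibition and higher numbers for weaker inhibition), a limit of the assay. Compound 2 `Cc1ccc(CC(=O)O)cc1NC(=O)c1c(C)cc(OC[C@@H]2CN(C)c3ccccc3O2)cc1C` gives > 10000 nM in this assay, also a limit. Among the measured compounds shown here, compound 3 `Cc1cc(OC[C@@H]2CN(C)c3ccccc3O2)ccc1C(=O)Nc1cc(CC(=O)O)ccc1Cl` gives 1800 nM in this assay, the only value reported as a number.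

Compound 1 and compound 2 differ by methyl in place of hydrogen on an aromatic carbon. The step that the two limits leave unreadable from compound 1 to compound 2 cannot be read because of the limit of > 10000 nM in this assay, at which 2 of the 3 values shown sit. Compound 4 `Cc1cc(C(=O)Nc2cc(CC(=O)O)ccc2Cl)c(C)cc1OC[C@@H]1CN(C)c2ccccc2O1` is not yet measured and differs from compound 3 by methyl in place of hydrogen on an aromatic carbon. This is the same kind of change as from compound 1 to compound 2, but the surroundings are not the same: in compound 2 the methyl sits ortho to a large group and para to a carboxymethyl group, whereas in compound 4 it sits ortho to a large group, meta to a large group and para to a methyl group. The difference between the cores of compound 1 and compound 3 is not broken down here. Since the earlier step is unreadable, the expectation rests on compound 3 alone, which gives 1800 nM. For compound 4 an expected step of a 2.2-fold higher number from compound 3 to compound 4 (0.35 log units; beyond the scatter) is taken. Compound 4 is therefore estimated at 4000 nM, between 1200 nM and 15000 nM.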

Compound 4, inhibition constant: 1800 nM
Compound 4: the middle estimate sits 2.2-fold (0.35 log units) above what was measured, and the stated range covers the measured number.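

In this assay, methyl in place of hydrogen on an aromatic carbon brings no change at the digits printed from compound 3 to compound 4 (within the scatter), so on the core of compound 3 this change leaves the read-out within the scatter. The same kind of change on the core of compound 1 cannot be read, as compound 1 and compound 2 each stand at a limit of the assay and not at a number: the limit of > 10000 nM in this assay, at which 2 of the 4 values shown sit. Among the compounds shown here, the new step therefore describes one core only, and it does not show that the change behaves alike on another core, as this series holds no second readable step of this kind for comparison.

The compounds shown leave open whether a methoxy group or an amine on the same aromatic carbon would also leave the read-out within the scatter. They also leave open how the several differences between the core of compound 1 and the core of compound 3 each bear on the read-out.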